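Ethyl to propyl on the secondary amine of compound 3

The compounds below may be only part of what the source reports. "The series", "measured", "known", "first", "only" and "open" are said of these compounds alone.

In a functional assay on HEK293 cells for agonist activity at 5-hydroxytryptamine receptor 7 (Homo sapiens), read by a luciferase reporter and beta-arrestin recruitment, with a stated time of 22 h (on this read-out higher numbers stand for an effect only at larger amounts of compound and lower numbers for an effect already at smaller amounts), compound 1 `CCCN(CCC)Cc1ccc(Cl)c(-c2ccccc2OC)c1` is reported as "not active" (no number reported), while compound 2 `COc1ccccc1-c1cc(C2CCN(C)C2)ccc1Cl` gives 646 nM; 650 nM (2 entries), the two entries agreeing closely (the several entries of compound 2 in this assay, 646 nM; 650 nM (2 entries)). Compound 3 `CCNCc1ccc(Cl)c(-c2ccccc2OC)c1` is likewise reported as "not active" (no number reported), with two further entries that also carry no single number; on the numbers shown it therefore stands without a measurable effect in this assay. Compound 4 `CCCNCc1ccc(Cl)c(-c2ccccc2OC)c1` differs from compound 3 by methyl in place of hydrogen on a saturated chain carbon, two bonds along the chain from an amine nitrogen. Since compound 3 shows no effect and compound 1, which bears two propyl groups on the same nitrogen, is also reported as inactive, no step beyond the scatter is expected in this assay. Compound 4 is therefore expected to give about 15000 nM, with a range from 3000 nM to 60000 nM, and most likely only a limit.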

Compound 4, half-maximal effective concentration: "not active" (no number reported)
Nothing numeric was reported for compound 4, and the estimate cannot be compared.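

Compound 3 and compound 4 both carry no number in this assay, so no step can be read between them, and nothing at hand bears on this result. As far as these compounds go, what the ethylamino to propylamino change does in this assay remains open.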